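This account rests on a few compounds, and the source may have more. Where it says the series, first, only, none or still open, it means among the compounds named here.

Compound 1 `COc1ccc(S(=O)(=O)N(Cc2ccc(C(C)C)cc2)[C@H](C)C(=O)NO)cc1`: 230 nM
Compound 2 `COc1ccc(S(=O)(=O)N(Cc2cc(C)on2)[C@H](C)C(=O)NO)cc1`: 230 nM
Compound 3 `COc1ccc(S(=O)(=O)N(CCn2cccc2)[C@H](C)C(=O)NO)cc1`: 170 nM

These three compounds share one core and differ only in the group attached to the saturated chain carbon bound to the sulfonamide nitrogen. In an assay on isolated protein for inhibition of bone morphogenetic protein 1 (Homo sapiens) (a lower number here means a stronger inhibitor, a higher number a weaker inhibitor), compound 3 has the lowest number of the three, yet this means little, since the gaps are small: a 1.4-fold lower number from compound 1 to compound 3 (0.13 log units; within the scatter) and a 1.4-fold lower number from compound 2 to compound 3 (0.13 log units; within the scatter), and between the other two no change at the digits printed from compound 1 to compound 2 (within the scatter). Whether the group is 4-isopropylphenyl, 5-methyl-1,2-oxazol-3-yl or (1H-pyrrol-1-yl)methyl, the number has stayed within the scatter.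

Compound 4 `COc1ccc(S(=O)(=O)N(Cc2cccc(Br)c2)[C@H](C)C(=O)NO)cc1` has not yet been measured. It differs from compound 3 in a single place: 3-bromophenyl in place of (1H-pyrrol-1-yl)methyl on a saturated chain carbon bound to a sulfonamide nitrogen. All three measured steps bear on this change. Each of them also swaps the group at this same position, and none of them moved the number beyond the scatter. The expectation for compound 4 in this assay is therefore a step of a 1.2-fold higher number from compound 3 to compound 4 (0.07 log units; within the scatter), that is, no change beyond the scatter. Compound 4 is estimated at 200 nM in this assay, with a range from 90 nM to 450 nM.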

Compound 4, half-maximal inhibitory concentration: 93 nM
Beside the measured number, compound 4's estimate is 2.2-fold (0.33 log units) above it; the measured number falls inside the stated range.
By their numbers in this assay, from the lowest: compounds 4, 3, 1 and 2 (each within the scatter of the next, the first and the last beyond it).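

Among the groups shown at this position, 3-bromophenyl is the only one that gives a step beyond the scatter in this assay, with a 2.5-fold lower number from compound 2 to compound 4 (0.39 log units; beyond the scatter) and a 2.5-fold lower number from compound 1 to compound 4 (0.39 log units; beyond the scatter), so the number here can respond to the group, though only modestly. Compound 1 also carries a six-membered aromatic ring of carbon only, in its 4-isopropylphenyl group, so such a ring alone does not go with the lower number, and the effect is also limited: a 1.8-fold lower number from compound 3 to compound 4 (0.26 log units; within the scatter) leaves compound 4 and compound 3 not separated from each other. Nothing measured here explains why 3-bromophenyl stands apart from the 5-methyl-1,2-oxazol-3-yl and 4-isopropylphenyl groups.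

The compounds shown leave open whether the bromine itself matters, which a plain phenyl or a 3-chlorophenyl group at this place would help to settle. Also open, as far as these compounds go, is how the number responds to a group of a different kind on the saturated chain carbon bound to the sulfonamide nitrogen, such as one carrying an amine or a carboxylic acid.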